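From 2,3-dichlorophenyl to 3,4-dihydroxyphenyl on a shared core

The source may hold more compounds than are shown below. What is called first, only, known or untested is meant among the compounds shown, and "the series" means these compounds.

In a functional assay on SW-620 cells (Homo sapiens) for cytotoxicity, read by MTT assay, with a stated time of 72 h (on this read-out higher numbers stand for weaker inhibition and lower numbers for stronger inhibition), compound 1 `COc1cccc(/C=C2\CCC/C(=C\c3ccccc3Cl)C2=O)c1OC` gives 10300 nM, compound 2 `COc1cccc(/C=C2\CCC/C(=C\c3ccccc3Br)C2=O)c1OC` gives 12100 nM, and compound 3 `COc1cccc(/C=C2\CCC/C(=C\c3cccc(Cl)c3Cl)C2=O)c1OC` gives 16300 nM. Compound 3 thus stands level with the other two compounds, as the measured steps show: a 1.6-fold higher number from compound 1 to compound 3 (0.20 log units; within the scatter) and a 1.3-fold higher number from compound 2 to compound 3 (0.13 log units; within the scatter). The remaining step, a 1.2-fold higher number from compound 1 to compound 2 (0.07 log units; within the scatter), also stays within the scatter.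

Compound 4 `COc1cccc(/C=C2\CCC/C(=C\c3ccc(O)c(O)c3)C2=O)c1OC` departs further from this small set. Its structural change is 3,4-dihydroxyphenyl in place of 2,3-dichlorophenyl on a double-bonded chain carbon bound to a double-bonded ring carbon. In words, 3,4-dihydroxyphenyl stands in place of 2,3-dichlorophenyl on a double-bonded chain carbon bound to a double-bonded ring carbon.

All three measured steps bear on this position, yet each involves only halogen substituents, and none brings in a hydroxy group. They show that these halogen changes left the numbers within the scatter, but they do not measure the new change directly. A moderate move toward a lower number in this assay is therefore expected only tentatively, and the range must stay wide. The estimated step is a 2.7-fold lower number from compound 3 to compound 4 (0.43 log units; beyond the scatter). For compound 4, the expected value is 6000 nM, with an estimated range from 1800 nM to 17000 nM.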

Compound 4, half-maximal inhibitory concentration: 6300 nM
Beside the measured number, compound 4's estimate is 1.1-fold (0.02 log units) below it; measured number inside the range.
By their numbers in this assay, from the lowest: compounds 4, 1, 2 and 3 (each within the scatter of the next, the first and the last beyond it).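

In this assay, for the compounds shown here, 3,4-dihydroxyphenyl is the first group at this position to give a step beyond the scatter, a 2.6-fold lower number from compound 3 to compound 4 (0.41 log units; beyond the scatter), showing that the position accepts a ring bearing hydrogen-bond donors and acceptors, which the halogen-bearing rings lack, without any loss of activity against these cells. The gain is modest and holds only against the 2,3-dichlorophenyl compound, since the same kind of exchange gives a 1.9-fold lower number from compound 2 to compound 4 (0.28 log units; within the scatter) and a 1.6-fold lower number from compound 1 to compound 4 (0.21 log units; within the scatter), and both of these steps stay within the scatter, leaving compound 4 level with the two compounds that carry a single halogen. Nothing in the data available here accounts for the step from the dichlorinated ring to the dihydroxylated one.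

The compounds shown leave open whether the free hydroxy groups themselves matter or whether any ring without halogen would serve as well, a question that a 3,4-dimethoxyphenyl group or an unsubstituted phenyl group at this place would address. They also leave open how an amine or a carboxylic acid on this ring would fare.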